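A few compounds are considered here, and "the series" means these few. Any claim that something is new, unique, unknown or untested is made for them only; others in the source may bear on it.

Among the measured compounds shown here, compound 1 `CCc1cccc(NC(=O)N[C@H](C)c2ccccc2)c1` gives 71% in an ADME assay on the whole organism with Oryza sativa as the target, tested at 1 uM (on this read-out higher numbers stand for a weaker effect at the one concentration tested and lower numbers for a stronger effect), the lowest of the three numbers measured so far. Compound 2 `CCc1cccc(NC(=O)N[C@@H](C)c2ccccc2)c1` gives 94% in this assay, and the step of a number 23 percentage points higher from compound 1 to compound 2 (beyond the scatter) goes with the fact that compounds 1 and 2 differ only in the configuration as drawn. For the measured compounds named here, compound 3 `CCOC(=O)c1ccc(NC(=O)N[C@H](C)c2ccccc2)cc1` gives 100% in this assay; no single-point step links it to compound 1.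

Compound 4 `CC(=O)c1cccc(NC(=O)N[C@H](C)c2ccccc2)c1` is the next case: acetyl in place of ethyl on an aromatic carbon. Going by the values given here, no measured step covers a change of this kind, since the only step on record is a change of configuration and does not speak to a substituent swap on the ring. The step of a number 11 percentage points higher from compound 1 to compound 4 (beyond the scatter) is therefore expected to be small, if any. Compound 4 is estimated at 82%, within 60% to 100%.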

Compound 4, a percentage reported as activity, at one concentration (the size of the read-out at that concentration, not a potency): 88%
The estimate for compound 4 lay 6 percentage points below the measured number; low and high end bracket the measured number.
By their numbers in this assay, from the lowest: compound 1; then compounds 4, 2 and 3 (each within the scatter of the next, the first and the last beyond it).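

Acetyl in place of ethyl on an aromatic carbon, meta to a large group, gives a number 17 percentage points higher from compound 1 to compound 4 (beyond the scatter), so in this assay this ring position responds to a change of substituent, while the earlier step concerned only the stereocentre. Of this pair, compound 1 with its ethyl gives the stronger effect. Nothing on record bears on the cause of this step.

Open, from the compounds shown here alone, is how a methoxy group, an amine or a longer chain at this position would read in this assay. Among the compounds shown here, also open is whether acetyl with the opposite configuration would show a step like the one between the ethyl compounds.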